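Propylamino to diisopropylamino in the chloro series

The compounds below may be only part of what the source reports. "The series", "measured", "known", "first", "only" and "open" are said of these compounds alone.

Measured in an ADME assay on the whole organism for inhibition, with Echinochloa crus-galli var. formosensis as the target, with a stated time of 4 days; a higher number here means a weaker inhibitor, a lower number a stronger inhibitor:
- compound 1 `CCCNc1nc(Cl)nc(N[C@@H](C)c2ccccc2)n1`: 15100 nM
- compound 2 `CCCNc1nc(Cl)nc(N[C@H](C)c2ccccc2)n1`: 33100 nM
- compound 3 `CC(C)Nc1nc(Cl)nc(N[C@@H](C)c2ccccc2)n1`: 11000 nM

Of these three, compound 2 carries the highest number, at 33100 nM. The measured step of a 2.2-fold higher number from compound 1 to compound 2 (0.34 log units; beyond the scatter) rests on (the fact that compounds 1 and 2 differ only in the configuration as drawn). Compound 4 `CC(C)N(c1nc(Cl)nc(N[C@H](C)c2ccccc2)n1)C(C)C` keeps the configuration of compound 2, so this step does not apply directly to the change at hand.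

That change is diisopropylamino in place of propylamino on an aromatic carbon. Among the measured compounds shown here, the one measured step at this nitrogen is a 1.4-fold lower number from compound 1 to compound 3 (0.14 log units; within the scatter). It is only a weak guide, since it is a much smaller change and was made with the other configuration. A modest shift towards a higher number in this assay is expected, with wide uncertainty, and this direction is a judgement from the size of the change alone. The expected change is a 1.8-fold higher number from compound 2 to compound 4 (0.26 log units; within the scatter). For compound 4 the estimated value is 60000 nM, with an expected range of 20000 nM to 200000 nM.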

Compound 4, half-maximal inhibitory concentration: 6610 nM
Compound 4: middle estimate off by 9.1-fold (0.96 log units), on the high side; measured number outside the range, below it.
By their numbers in this assay, from the lowest: compounds 4, 3 and 1 (each within the scatter of the next, the first and the last beyond it); then compound 2.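

In this assay, among the compounds shown here, the propylamino position gives a step beyond the scatter for the first time: diisopropylamino in place of propylamino gives (a 5.0-fold lower number from compound 2 to compound 4 (0.70 log units; beyond the scatter)). The earlier change at this nitrogen, isopropyl in place of propyl, stayed within the scatter (a 1.4-fold lower number from compound 1 to compound 3 (0.14 log units; within the scatter)). The position therefore accepts diisopropylamino, with 7 heavy atoms and 0 hydrogen-bond donors, without any loss in this assay, so in this configuration the hydrogen-bond donor of propylamino is not needed for the number to fall; nothing shown gives a reason for the step.

From the compounds shown here alone, whether the step carries over to the opposite configuration at the stereocentre remains open. Also open, going by these compounds, is how diethylamino, a longer chain such as dibutylamino, or a ring amine such as morpholine would behave at this position.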